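A few compounds are considered here, and "the series" means these few. Any claim that something is new, unique, unknown or untested is made for them only; others in the source may bear on it.

Compound 2 `Cc1nc(C)n(CC(=O)N2CCN(c3sc(C(F)(F)F)nc3-c3cnc(C4CC4)nc3)C[C@H]2C)n1` gives 349 nM in a functional assay on U2OS cells for antagonist activity at C-X-C chemokine receptor type 3 (Homo sapiens), read by beta-arrestin recruitment; on this read-out lower numbers stand for stronger inhibition and higher numbers for weaker inhibition; compound 1 `Cc1ncc(-c2nc(C(F)(F)F)sc2N2CCN(C(=O)Cn3nc(C)nc3C)[C@H](C)C2)cn1` gives 578 nM in this assay, and the step of a 1.7-fold lower number from compound 1 to compound 2 (0.22 log units; within the scatter) leaves the two within the scatter of each other. Compound 3 `CCOc1ccc(-c2nc(C(F)(F)F)sc2N2CCN(C(=O)Cn3nc(C)nc3C)[C@H](C)C2)cn1` differs from compound 2 by 6-ethoxypyridin-3-yl in place of 2-cyclopropylpyrimidin-5-yl on an aromatic carbon. For the measured compounds named here, the single measured step only exchanges cyclopropyl for methyl on an aromatic carbon and stays within the scatter; no measured step replaces the whole group, so no direction is indicated. In this assay compound 3 is expected near 400 nM, between 130 nM and 1300 nM. The step of a 1.1-fold higher number from compound 2 to compound 3 (0.06 log units; within the scatter) is thus estimated to remain within the scatter.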

Compound 3, half-maximal inhibitory concentration: 505 nM
Compound 3: the middle estimate sits 1.3-fold (0.10 log units) below what was measured, and the stated range covers the measured number.
By their numbers in this assay, from the lowest: compounds 2, 3 and 1 (each within the scatter of the next).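

In this assay, exchange of the whole aromatic group at this position, not only its small substituent, now has a reading: 6-ethoxypyridin-3-yl in place of 2-cyclopropylpyrimidin-5-yl gives a 1.4-fold higher number from compound 2 to compound 3 (0.16 log units; within the scatter), and 6-ethoxypyridin-3-yl in place of 2-methylpyrimidin-5-yl gives a 1.1-fold lower number from compound 1 to compound 3 (0.06 log units; within the scatter). The pyridine with its ethoxy group and both pyrimidines thus stand level here. No supporting data explain this result. Open, going by these compounds, is whether an amine, a carboxylic acid or a chain longer than ethoxy on this aromatic ring would move the number beyond the scatter.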